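Replacing the 1-benzofuran-5-yl group of compound 2

This account rests on a few compounds, and the source may have more. Where it says the series, first, only, none or still open, it means among the compounds named here.

Compound 1 `Cn1c(=O)c(S(=O)(=O)c2ccc(F)cc2F)cc2cnc(Nc3ccc4sccc4c3)nc21`: 500 nM
Compound 2 `Cn1c(=O)c(S(=O)(=O)c2ccc(F)cc2F)cc2cnc(Nc3ccc4occc4c3)nc21`: 15000 nM

Both values come from a functional assay on K562 cells (Homo sapiens) for inhibition, read by trypan blue exclusion, with a stated time of 72 h; a lower number here means a stronger inhibitor, a higher number a weaker inhibitor. Compound 2, at 15000 nM, has the higher of the two numbers and is the weaker inhibitor. The next structure, compound 3 `Cn1c(=O)c(S(=O)(=O)c2ccc(F)cc2F)cc2cnc(Nc3ccncn3)nc21`, keeps the shared core and differs from compound 2 on the same nitrogen: pyrimidin-4-yl in place of 1-benzofuran-5-yl on a nitrogen on an aromatic ring. In words, pyrimidin-4-yl stands in place of 1-benzofuran-5-yl on a nitrogen on an aromatic ring.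

Among the compounds with values here, one measured step bears on this change, the exchange of 1-benzothiophen-5-yl for 1-benzofuran-5-yl on that nitrogen: a 30-fold higher number from compound 1 to compound 2 (1.48 log units; beyond the scatter). This large step shows that the number in this assay can move strongly with the group at this place. However, neither group in that step has a six-membered aromatic ring with 2 hetero atoms, so it suggests a possible size but no direction. No clear shift is therefore expected, and the uncertainty is wide. The expected change is a 1.5-fold lower number from compound 2 to compound 3 (0.18 log units; within the scatter). For compound 3 the estimated value is 10000 nM, with an expected range from 1500 nM to 40000 nM.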

Compound 3, half-maximal inhibitory concentration: 30000 nM
Compound 3: middle estimate off by 3.0-fold (0.48 log units), on the low side; measured number inside the range.
By their numbers in this assay, from the lowest: compound 1; then compounds 2 and 3 (each within the scatter of the next).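

Swapping the two-ring 1-benzofuran-5-yl for the single-ring pyrimidin-4-yl, which has fewer heavy atoms and one more hydrogen-bond acceptor, gives in this assay (a 2.0-fold higher number from compound 2 to compound 3 (0.30 log units; within the scatter)), so this exchange on the nitrogen does not separate the two compounds beyond the usual scatter. The wider comparison is a 60-fold higher number from compound 1 to compound 3 (1.78 log units; beyond the scatter) and is large, so compound 1 stands apart from both compound 2 and compound 3, and among these three groups only 1-benzothiophen-5-yl gives a number beyond the scatter of the others; having two rings is thus not enough for a low number, as compound 2 goes against that reading. Nothing available explains why these groups behave as they do.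

The three compounds leave open whether the low number of compound 1 is tied to the sulfur atom of its 1-benzothiophen-5-yl group or to some other feature of that group. They also leave open how the number would respond on this nitrogen to a plain phenyl group, or to a phenyl group carrying an amine or a carboxylic acid.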